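This account rests on a few compounds, and the source may have more. Where it says the series, first, only, none or still open, it means among the compounds named here.

Compounds and values:
compound 1 `COc1cccc(CNCc2c(-c3nnc(SC(C)C)n3-c3ccccc3)n(C)c3ccc(F)cc23)c1` gives 6.42
compound 2 `CC(C)Sc1nnc(-c2c(CNCC3CC3)c3cc(F)ccc3n2C)n1-c1ccccc1` gives 5.4
compound 3 `CC(C)Sc1nnc(-c2c(CNc3cnccn3)c3ccccc3n2C)n1-c1ccccc1` gives 4.22

In a physicochemical assay for lipophilicity (a higher number here means a more lipophilic compound, a lower number a more polar compound), compound 3 stands lowest of the three measured compounds; compound 2 is its nearest neighbour, and compound 1 lies furthest from it. Compound 4 `CC(C)Sc1nnc(-c2c(CNCCN3CCCC3)c3ccccc3n2C)n1-c1ccccc1` has not yet been measured in this assay. It differs from compound 3 in one place: 2-(pyrrolidin-1-yl)ethyl in place of pyrazin-2-yl on an amine nitrogen. Within the data shown here, no measured step covers this exact change. Among the measured compounds shown here, the one measured step, a number 1.02 log units lower from compound 1 to compound 2 (beyond the scatter), shows that exchanging the group on the amine nitrogen side of this core can shift this assay by a large amount, and the values of compound 2 and compound 3 show a further gap of similar size between a saturated and an aromatic group in that place. Since compound 4 carries a saturated group there, as compound 2 does, it is expected to land between compound 3 and compound 2. On this basis the expected change for compound 4 is a number 0.58 log units higher from compound 3 to compound 4 (beyond the scatter). Compound 4 is therefore estimated at 4.8, with a range from 3.8 to 5.8.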

Compound 4, partition coefficient: 4.83
Beside the measured number, compound 4's estimate is 0.03 log units below it, within the range that was stated.
By their numbers in this assay, from the lowest: compound 3; then compound 4; then compound 2; then compound 1.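

In this assay the exchange on the amine nitrogen gives a number 0.61 log units higher from compound 3 to compound 4 (beyond the scatter), so a non-aromatic ring-bearing chain entering for an aromatic ring here raises the number. The earlier step ran the other way, with a number 1.02 log units lower from compound 1 to compound 2 (beyond the scatter), also as a non-aromatic ring replaced an aromatic one, though there the ring sat on a saturated chain carbon and not directly on the amine nitrogen; leaving an aromatic ring therefore fixes no direction across these two steps. Nothing in the data shown accounts for either step.

The compounds shown leave open whether the number follows the ring or the chain of 2-(pyrrolidin-1-yl)ethyl, which a plain ethyl group or a longer chain ending in pyrrolidine would separate. They also leave open whether a morpholine or a piperidine at the end of that chain would read like pyrrolidine.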